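Swapping methyl for fluoro on a tricyclic nicotinic ligand

The compounds below may be only part of what the source reports. "The series", "measured", "known", "first", "only" and "open" are said of these compounds alone.

Measured so far:
compound 1, `Cc1ccc2c(c1)C1CNCC2C1`: 1.6 nM
compound 2, `Cc1nc2cc3c(cc2[nH]1)C1CNCC3C1`: 0.1 nM
compound 3, `CC(C)Cn1cnc2cc3c(cc21)C1CNCC3C1`: 0.3 nM

Of the compounds shown here, three have been tested in an assay on HEK293 cells for binding affinity to Neuronal acetylcholine receptor; alpha4/beta2 (Homo sapiens); a higher number here means a weaker inhibitor, a lower number a stronger inhibitor. Compound 1 carries a methyl group on the carbon-only aromatic ring of the shared core, and in this assay compound 1 gives 1.6 nM. Compound 2 and compound 3 each add a further ring fused onto that core, and both give lower numbers than compound 1, that is, tighter binding; their gaps to compound 1 lie beyond the usual scatter of repeated measurements. Among the three, compound 1 therefore stands with the highest number.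

The next compound is compound 4, `Fc1ccc2c(c1)C1CNCC2C1`. It keeps the whole core of compound 1 and differs from it in one place: fluoro in place of methyl on an aromatic carbon. Fluoro and methyl are each a single heavy atom, so the size of the molecule barely changes, and no donors, acceptors or charges are gained or lost.

Going by the values given here, no measured pair shows this particular change, so the expectation rests on compound 1 alone. Compound 4 is expected to give 2.5 nM in this assay, with a likely range from 0.8 nM to 8 nM. The expected step of a 1.6-fold higher number from compound 1 to compound 4 (0.19 log units; within the scatter) is small, probably a mild weakening, and may well fall within the scatter.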

Compound 4, inhibition constant: 1.1 nM
Estimate against measurement, compound 4: 2.3-fold (0.36 log units) above; the measured number falls inside the stated range.
By their numbers in this assay, from the lowest: compound 2; then compound 3; then compounds 4 and 1 (each within the scatter of the next).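

In this assay, fluoro in place of methyl on this aromatic carbon gives a 1.5-fold lower number from compound 1 to compound 4 (0.16 log units; within the scatter) and so leaves the two compounds indistinguishable by this measurement. Going by these compounds alone, this is the first pair that differs in only one place, and it shows that the methyl group itself is not required for binding of this order at this position, which is meta to a fused ring and para to a fused ring. Nothing available here explains why the two groups read alike in this assay.

Methyl and fluoro are each a single heavy atom, so the pair says little about what a methoxy group, a nitrile or an amine would do on this same carbon. From the compounds shown here alone, it also remains open whether fluoro would read the same way on compounds that carry a further fused ring, such as compound 2 and compound 3, since neither of those has a partner differing from it in one place.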